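The source may report more compounds than this note shows. Statements on the series, on what has been measured and on what is new or still open speak of the compounds shown alone.

Measured in a functional assay on DLD-1 cells (Homo sapiens) for inhibition, read by MTT assay, with a stated time of 72 h; a lower number here means a stronger inhibitor, a higher number a weaker inhibitor:
- Compound 1 `COc1cc(Oc2cccc(Nc3ccccc3)c2)cc(OC)c1CNCc1ccccc1`: 5220 nM
- Compound 2 `COc1cc(Oc2cccc(Nc3ccccc3)c2)cc(OC)c1CNCc1ccc(F)cc1`: 2650 nM
- Compound 3 `COc1cc(Oc2cccc(Nc3ccccc3)c2)cc(OC)c1CNC(C)C`: > 20000 nM (a limit, not a number)

Compound 3 has no number on this read-out, only a limit: the limit of > 20000 nM in this assay, at which 1 of the 3 values shown sits. Compound 4 `COc1cc(Oc2cccc(Nc3ccccc3)c2)cc(OC)c1CNC1CC1` has cyclopropyl in place of isopropyl on an amine nitrogen, (cyclopropyl in place of isopropyl on an amine nitrogen).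

For the measured compounds named here, no measured step exchanges one of these two groups for the other, so the evidence is indirect. Two steps lead to compound 3: an at least 3.8-fold higher number from compound 1 to compound 3 (0.58 log units; beyond the scatter) and an at least 7.5-fold higher number from compound 2 to compound 3 (0.87 log units; beyond the scatter). Both lie beyond the scatter, and both are bounded on one side only. They show what was measured on going from the benzyl of compound 1 and the 4-fluorobenzyl of compound 2 to isopropyl. The remaining step, a 2.0-fold lower number from compound 1 to compound 2 (0.29 log units; within the scatter), lies within the scatter and has little bearing here.

Compound 4, like compound 3, carries neither benzyl group, so it is expected to stay in the same region of this assay. No step beyond the scatter is expected, and no direction is favoured. The step is estimated as an at least 1.1-fold lower number from compound 3 to compound 4 (0.04 log units; that floor lies within the scatter), and a reading at the limit is expected about as often as a number. Compound 4 is estimated at 18000 nM, with an expected range of 8000 nM to 40000 nM.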

Compound 4, half-maximal inhibitory concentration: > 20000 nM
Compound 4 was reported as a limit; the forecaster's own chance of this, stated with the estimate: 50%; at least 1.1-fold (0.04 log units) between middle value and limit.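

In this assay, compound 3 and compound 4 both stand as a limit and not as a number: the limit of > 20000 nM in this assay, at which 2 of the 4 values shown sit.

The step between these two cannot be read, so no order can be given for isopropyl and cyclopropyl on this amine nitrogen. The loss on leaving the benzyl groups no longer rests on isopropyl alone, with an at least 3.8-fold higher number from compound 1 to compound 4 (0.58 log units; beyond the scatter) and an at least 7.5-fold higher number from compound 2 to compound 4 (0.87 log units; beyond the scatter), both beyond the scatter and bounded on one side only, and the three-membered ring of cyclopropyl does not bring back a measurable number in this series.

Going by these compounds, the full size of these losses remains open, as only their floors can be read while compound 3 and compound 4 have no numbers. Also open, on these data alone, is what the benzyl and 4-fluorobenzyl groups contribute, which a cyclohexylmethyl group, a 2-phenylethyl group or a pyridinylmethyl group on the same amine nitrogen would help to separate, by showing whether an aromatic ring or the longer chain carries the difference.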